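Formyl to hydroxymethyl on the vinyl arm of two cores

This account rests on a few compounds, and the source may have more. Where it says the series, first, only, none or still open, it means among the compounds named here.

Compound 1 `Cc1cn(/C=C/C=O)c(=O)[nH]c1=O` and compound 2 `Cc1cn(/C=C/CO)c(=O)[nH]c1=O` carry a three-carbon vinyl arm on a bare core; compound 3 `Cc1cn([C@H]2C[C@H](O)[C@@H](CO)O2)c(=O)n(/C=C/C=O)c1=O` and compound 4 `Cc1cn([C@H]2C[C@H](O)[C@@H](CO)O2)c(=O)n(/C=C/CO)c1=O` carry the same arm on a sugar-bearing core. The difference between the two cores is not broken down here.

In a functional assay on HeLa cells (Homo sapiens) for inhibition (a higher number here means a weaker inhibitor, a lower number a stronger inhibitor), compound 1 gives 23000 nM. Compound 2 in this assay reaches only > 100000 nM, which is a limit of the measurement and not a number. The change is hydroxymethyl in place of formyl on a double-bonded chain carbon bound to a double-bonded chain carbon, and the step it made is an at least 4.3-fold higher number from compound 1 to compound 2 (0.63 log units; beyond the scatter). The size of this step is known only as a bound because of the limit of > 100000 nM in this assay, at which 1 of the 3 values shown sits.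

Compound 3 in this assay gives 500 nM, the lowest number among the measured compounds. Compound 4 differs from compound 3 by hydroxymethyl in place of formyl on a double-bonded chain carbon bound to a double-bonded chain carbon, the same change as that from compound 1 to compound 2, at the same place.

On the sugar-bearing core the same change is expected to weaken inhibition again; the expected step of a 16-fold higher number from compound 3 to compound 4 (1.20 log units; beyond the scatter) is set beside the measured at least 4.3-fold higher number from compound 1 to compound 2 (0.63 log units; beyond the scatter), allowing that the measured step is only a bound and the true loss may be larger. Compound 4 is therefore estimated at 8000 nM in this assay. For compound 4 the range of that estimate runs from 2000 nM to 50000 nM, with some chance that only a limit is reported.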

Compound 4, half-maximal inhibitory concentration: 5000 nM
The estimate for compound 4 lay 1.6-fold (0.20 log units) above the measured number; measured number inside the range.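

On the sugar-bearing core, hydroxymethyl in place of formyl on a double-bonded chain carbon bound to a double-bonded chain carbon again gives a weaker inhibitor in this assay, with a measured step of a 10-fold higher number from compound 3 to compound 4 (1.00 log units; beyond the scatter). Across these two matched pairs, the direction of the change therefore carries from one core to the other, and no pair shown goes against it, but the comparison of sizes stays unsettled: the same change on two cores in this assay, an at least 4.3-fold higher number (0.63 log units; beyond the scatter) from compound 1 to compound 2 and a 10-fold higher number (1.00 log units; beyond the scatter) from compound 3 to compound 4; the limit leaves it open whether they differ
The value of compound 2 is a limit and not a number, so the loss on the bare core has no upper end, and these data do not show that the size of the step transfers between cores: the limit of > 100000 nM in this assay, at which 1 of the 4 values shown sits.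

Two pairs on two cores say nothing about how the change reads on any further core, and the separate contribution of the sugar-bearing core remains unresolved here. Going by these compounds, it also remains open whether formyl is the only arm end that preserves inhibition at this place, or whether a carboxylic acid, an amine or a longer chain would hold the level of compound 3 at 500 nM in this assay.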